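Replacing an imidazole with a nitrile: what happens to permeability

The source may report more compounds than this note shows. Statements on the series, on what has been measured and on what is new or still open speak of the compounds shown alone.

Of the compounds shown here, three sharing one core have been measured in an ADME assay on MDCK-MDR1 cells (Canis lupus familiaris) for permeability, in the apical to basolateral direction, with a stated time of 180 min; on this read-out higher numbers stand for higher permeability and lower numbers for lower permeability. Compound 1 `CN(C)CCC(=O)Nc1ccc([C@H]2[C@@H](F)[C@@H](F)C[C@@H](F)[C@H]2F)cc1` gives 3.7 10^-6 cm/s. Compound 2 `NC(=O)CCNC(=O)c1ccc([C@H]2[C@@H](F)[C@@H](F)C[C@@H](F)[C@H]2F)cc1` gives 0.4 10^-6 cm/s, and compound 3 `O=C(Cn1ccnc1)Nc1ccc([C@H]2[C@@H](F)[C@@H](F)C[C@@H](F)[C@H]2F)cc1` gives 0.9 10^-6 cm/s. Among these three numbers compound 3 stands second highest: compound 1 lies above it and compound 2 below it, both gaps beyond the scatter. The two measured steps are a 9.3-fold lower number from compound 1 to compound 2 (0.97 log units; beyond the scatter) and a 4.1-fold lower number from compound 1 to compound 3 (0.61 log units; beyond the scatter).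

Compound 4 `N#CCC(=O)Nc1ccc([C@H]2[C@@H](F)[C@@H](F)C[C@@H](F)[C@H]2F)cc1` has not yet been measured. It differs from compound 3 in one place: cyano in place of 1H-imidazol-1-yl on a saturated chain carbon bound to a carbonyl carbon. Within the data shown here, no measured step swaps these two groups, so the step from compound 1 to compound 3 is the only one touching the same position, and it changed a different pair of groups. With that little to go on, the expected outcome for compound 4 is a small rise, near the edge of the scatter, namely a 1.8-fold higher number from compound 3 to compound 4 (0.25 log units; within the scatter). The estimate for compound 4 in this assay is therefore 1.6 10^-6 cm/s, with a range from 0.6 10^-6 cm/s to 4.5 10^-6 cm/s.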

Compound 4, apparent permeability: 16 10^-6 cm/s
Estimate against measurement, compound 4: 10-fold (1.00 log units) below; the measured number lies above the stated range.
By their numbers in this assay, from the lowest: compound 2; then compound 3; then compound 1; then compound 4.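

Among these compounds, on a saturated chain carbon bound to a carbonyl carbon, the choice of group can move the number in this assay much further than the earlier compounds showed, with cyano in place of 1H-imidazol-1-yl giving a large rise (an 18-fold higher number from compound 3 to compound 4 (1.25 log units; beyond the scatter)). Cyano also outperforms the (dimethylamino)methyl group at this place (a 4.3-fold higher number from compound 1 to compound 4 (0.64 log units; beyond the scatter)), and the change of ((cyanomethyl)carbonyl)amino for (2-carbamoylethyl)carbamoyl on an aromatic carbon gives the largest step of the set (a 40-fold higher number from compound 2 to compound 4 (1.60 log units; beyond the scatter)), so compound 4 stands highest of the four. Nothing measured here accounts for these rises.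

Still open, on these data alone, is whether cyano is special, or whether a primary amine, a hydroxyl or a carboxylic acid on this chain carbon would give a similar number. Also open, as far as these compounds go, is whether a longer chain ending in cyano would hold the number of compound 4.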